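Swapping a fluorophenyl for a naphthyl on a thioether

This account rests on a few compounds, and the source may have more. Where it says the series, first, only, none or still open, it means among the compounds named here.

Measured compounds:
Compound 1 `Nc1ccccc1NC(=O)/C=C/c1ccc(CSc2ccc(F)cc2)cc1`: 20.2%
Compound 2 `Nc1ccccc1NC(=O)c1ccc(CSc2ccc(C(F)(F)F)cn2)cc1`: 25.8%
Compound 3 `COc1ccc(SCc2ccc(C(=O)Nc3ccccc3N)cc2)cc1`: 90.1%

In a functional assay on HCT-116 cells (Homo sapiens) for inhibition, read by CCK-8 assay, with a stated time of 72 h, tested at 8 uM (on this read-out higher numbers stand for more inhibition of growth at the one concentration tested and lower numbers for less inhibition of growth), compound 1 sits at the low end of the three numbers. Compound 2 lies within the usual scatter of it, so the two cannot be told apart, while compound 3 stands far above it, beyond the scatter. Going by the values given here, no two measured compounds differ in only one place, so no measured step is at hand.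

Compound 4 `Nc1ccccc1NC(=O)/C=C/c1ccc(CSc2cccc3ccccc23)cc1` is the next compound, not yet measured. It differs from compound 1 in one spot: naphthalen-1-yl in place of 4-fluorophenyl on a sulfur. In this assay the step of a number 9.8 percentage points higher from compound 1 to compound 4 (within the scatter) is expected to be a small rise that does not clearly reach beyond the scatter. Compound 4 is therefore estimated at 30%, with a range from 10% to 60%.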

Compound 4, percent growth inhibition at one concentration: 35.2%
Beside the measured number, compound 4's estimate is 5.2 percentage points below it, within the range that was stated.
By their numbers in this assay, from the lowest: compounds 1, 2 and 4 (each within the scatter of the next, the first and the last beyond it); then compound 3.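

Going by these compounds alone, this is the first one-place step that can be read here: in this assay, naphthalen-1-yl in place of 4-fluorophenyl on a sulfur gives a number 15 percentage points higher from compound 1 to compound 4 (beyond the scatter), a modest gain. The group on this sulfur can therefore shift growth inhibition while the rest of compound 1 stays the same. Nothing measured here explains the gain.

Going by these compounds, it remains open whether a plain phenyl, a carboxylic acid on the ring or an amine on the ring would change the number in the same way. Whether this swap would have the same effect in the core of compound 3 is also unknown.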